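The source may report more compounds than this note shows. Statements on the series, on what has been measured and on what is new or still open speak of the compounds shown alone.

Measured so far in a functional assay on RPMI-8226 cells (Homo sapiens) for inhibition, read by sulforhodamine B assay, with a stated time of 48 h, tested at 10 uM; a higher number here means more inhibition at the concentration tested (going by the name of the read-out), a lower number less inhibition:
- compound 1 `c1ccc2c(-c3cn4ccnc4c(-c4ccc5ncn(C6CCCCC6)c5c4)n3)cccc2c1` gives 22.9%
- compound 2 `CC(=O)c1ccc(-c2cn3ccnc3c(-c3ccc4ncn(C5CCCCC5)c4c3)n2)cc1` gives 20.8%
- compound 3 `Clc1ccc(-c2cn3ccnc3c(-c3ccc4ncn(C5CCCCC5)c4c3)n2)cc1` gives 19%

Compound 3 holds the lowest of the three numbers, yet each step toward it stays within the scatter: a number 3.9 percentage points lower from compound 1 to compound 3 (within the scatter) and a number 1.8 percentage points lower from compound 2 to compound 3 (within the scatter). Compound 4 `Fc1ccccc1-c1cn2ccnc2c(-c2ccc3ncn(C4CCCCC4)c3c2)n1` keeps the shared core of compound 3 and changes only the aryl group: 2-fluorophenyl in place of 4-chlorophenyl on an aromatic carbon. Within the data shown here, three measured steps bear on such swaps of the aryl group, and all are small: a number 2.1 percentage points lower from compound 1 to compound 2 (within the scatter), a number 3.9 percentage points lower from compound 1 to compound 3 (within the scatter), a number 1.8 percentage points lower from compound 2 to compound 3 (within the scatter). On that basis no step beyond the scatter is expected, so the estimated change is a number 1 percentage points higher from compound 3 to compound 4 (within the scatter). Compound 4 is therefore expected to give about 20% in this assay, with a likely range from 12% to 28%.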

Compound 4, a percentage reported as inhibition, at one concentration (the size of the read-out at that concentration, not a potency): 42.4%
For compound 4 the middle estimate is 22.4 percentage points below the measured one; the measured number lies above the stated range.
By their numbers in this assay, from the lowest: compounds 3, 2 and 1 (each within the scatter of the next); then compound 4.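

In this assay, this position on the shared core proves responsive to the aryl group: with 2-fluorophenyl there is a number 23.4 percentage points higher from compound 3 to compound 4 (beyond the scatter), a number 21.6 percentage points higher from compound 2 to compound 4 (beyond the scatter) and a number 19.5 percentage points higher from compound 1 to compound 4 (beyond the scatter), whereas the three earlier aryl groups stayed within the scatter of one another. Going from 4-chlorophenyl to 2-fluorophenyl changes both the halogen and where it sits on the phenyl ring. Nothing available explains the rise.

Still open, on these data alone, is whether the halogen or its place on the ring matters. 2-Chlorophenyl, 4-fluorophenyl and 2-aminophenyl at this position could help separate those two changes.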